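Swapping methoxy for fluoro on two related cores

The compounds below may be only part of what the source reports. "The series", "measured", "known", "first", "only" and "open" are said of these compounds alone.

Compound 1 `COc1ccc2c(c1)-c1cnc(n1C)OCCCCCCCCO2` and compound 2 `Cn1c2cnc1OCCCCCCCCOc1ccc(F)cc1-2` share one core; compound 3 `C=CCCCCOc1ccc(OC)cc1-c1cnc(OCCC=C)n1C` carries a different core, and the difference between the two cores is not broken down here. In a functional assay on T98G cells (Homo sapiens) for inhibition, read by colorimetric assay and MTT assay, with a stated time of 72 h (on this read-out lower numbers stand for stronger inhibition and higher numbers for weaker inhibition), compound 1 gives 68000 nM and compound 2 gives 77000 nM, so the change fluoro in place of methoxy on an aromatic carbon made a step of a 1.1-fold higher number from compound 1 to compound 2 (0.05 log units; within the scatter). Compound 3 gives 74000 nM, close to both. Compound 4 `C=CCCCCOc1ccc(F)cc1-c1cnc(OCCC=C)n1C` is not yet measured; it differs from compound 3 by fluoro in place of methoxy on an aromatic carbon. This is the same kind of change as before, though the ring here is meta to a large group and para to a (hex-5-en-1-yl)oxy group rather than part of a fused system. Because the earlier step was a 1.1-fold higher number from compound 1 to compound 2 (0.05 log units; within the scatter), the step from compound 3 to compound 4 is expected to be about a 1.1-fold higher number from compound 3 to compound 4 (0.03 log units; within the scatter). Compound 4 is therefore estimated at 80000 nM, likely between 40000 nM and 160000 nM.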

Compound 4, half-maximal inhibitory concentration: 87000 nM
Beside the measured number, compound 4's estimate is 1.1-fold (0.04 log units) below it; the measured number falls inside the stated range.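

In this assay, fluoro in place of methoxy on an aromatic carbon gave a 1.2-fold higher number from compound 3 to compound 4 (0.07 log units; within the scatter), and the same change on the other core reads alike: the same change on two cores in this assay, a 1.1-fold higher number (0.05 log units; within the scatter) from compound 1 to compound 2 and a 1.2-fold higher number (0.07 log units; within the scatter) from compound 3 to compound 4, 1.0-fold (0.02 log units) apart, within the scatter of two such steps

So on both cores shown, this swap leaves the number within the usual scatter, and in that limited sense the result carries from one core to the other. It does not show that a change with a real effect would carry over, as neither step here rises above the scatter.

The compounds shown leave open whether another group on that aromatic carbon, such as an amine or a carboxylic acid, would give a step beyond the scatter. They also leave open how the difference between the two cores itself bears on the numbers.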